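A few compounds are considered here, and "the series" means these few. Any claim that something is new, unique, unknown or untested is made for them only; others in the source may bear on it.

Working notes on the series. In an assay on isolated protein for inhibition of thyroid hormone receptor beta (Homo sapiens), read by fluorescence, with a stated time of 30 min (on this read-out lower numbers stand for stronger inhibition and higher numbers for weaker inhibition), compound 1 `COc1cc(C(=O)N2CCC(O)C(C)C2)cc2nc(NCc3cc(Cl)ccn3)oc12` gives 190 nM, the lowest of the two numbers recorded so far. For the measured compounds named here, compound 2 `COc1cc(C(=O)N2CCC(O)C(C)C2)cc2nc(N[C@@H](C)c3cccc(Cl)c3)oc12` gives 5100 nM in this assay, and the single measured step, a 27-fold higher number from compound 1 to compound 2 (1.43 log units; beyond the scatter), concerns the substituent on the ring nitrogen and not the carbonyl carbon. Compound 3 `COc1cc(C(=O)N2CC(C)OCC2CCO)cc2nc(NCc3cc(Cl)ccn3)oc12` differs from compound 1 by 5-(2-hydroxyethyl)-2-methylmorpholin-4-yl in place of 4-hydroxy-3-methylpiperidin-1-yl on a carbonyl carbon. Going by the values given here, no measured step touches this carbonyl-side change, so the step from compound 1 to compound 2 gives no guidance on direction or size here; it only shows that the series can move far in this assay. Lacking any relevant comparison, the expectation for compound 3 is a step of a 1.7-fold higher number from compound 1 to compound 3 (0.23 log units; within the scatter), not clearly beyond the scatter in either direction. Compound 3 is therefore estimated at 320 nM in this assay, with a range from 80 nM to 1300 nM.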

Compound 3, half-maximal inhibitory concentration: 29 nM
The estimate for compound 3 lay 11-fold (1.04 log units) above the measured number; measured number outside the range, below it.
By their numbers in this assay, from the lowest: compound 3; then compound 1; then compound 2.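

The carbonyl-side position, which the earlier step did not touch, proves responsive in this assay: with the rest of the molecule unchanged, 5-(2-hydroxyethyl)-2-methylmorpholin-4-yl in place of 4-hydroxy-3-methylpiperidin-1-yl gives a 6.6-fold lower number from compound 1 to compound 3 (0.82 log units; beyond the scatter). The entering group differs in several features at once, with more heavy atoms, an added ring hetero atom and an added hydrogen-bond acceptor, while the hydrogen-bond donor count stays the same, so the step cannot be assigned to any one of them. Nothing available accounts for this step.

Still open, from the compounds shown here alone, is whether the hydroxyl of the 2-hydroxyethyl chain matters, which a 2-methoxyethyl chain, a carboxylic acid or a primary amine at that place would test. Also open, going by these compounds, is whether the lower number carries over to compounds bearing 1-(3-chlorophenyl)ethyl on the nitrogen.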